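The source may hold more compounds than are shown below. What is called first, only, known or untested is meant among the compounds shown, and "the series" means these compounds.

Of the compounds shown here, two sharing one core have been measured in an assay on HeLa cells for binding affinity to 5-hydroxytryptamine receptor 6 (Homo sapiens); on this read-out lower numbers stand for stronger inhibition and higher numbers for weaker inhibition. Compound 1 `COc1ccc(NS(=O)(=O)c2cccc(C#N)c2)cc1N1CCN(C)CC1` gives 63.1 nM. Compound 2 `COc1ccc(NS(=O)(=O)c2cccc([N+](=O)[O-])c2)cc1N1CCN(C)CC1`, which carries a nitro in place of cyano on an aromatic carbon, gives 79.4 nM. Going by the values given here, the single measured step, a 1.3-fold higher number from compound 1 to compound 2 (0.10 log units; within the scatter), is within the scatter. Compound 2 thus holds the highest of the two numbers shown, but its gap to compound 1 is too small to count as a real difference.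

Compound 3 `COc1ccc(NS(=O)(=O)c2ccc(Br)cc2)cc1N1CCN(C)CC1` has not yet been measured. Its difference from compound 2 is 4-bromophenyl in place of 3-nitrophenyl on a sulfonyl sulfur. Among the compounds with values here, no measured step involves a bromine or exchanges the whole ring on the sulfonyl sulfur, so the one measured step of a 1.3-fold higher number from compound 1 to compound 2 (0.10 log units; within the scatter) bears on it only loosely: it shows that swapping one group on that ring left the number within the scatter. On that basis the estimate for compound 3 is a step of a 1.1-fold lower number from compound 2 to compound 3 (0.05 log units; within the scatter), that is, no change beyond the scatter is expected. The estimated value for compound 3 in this assay is 70 nM, with a range from 25 nM to 200 nM, kept wide for want of a directly comparable step.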

Compound 3, inhibition constant: 5.01 nM
Compound 3: the middle estimate sits 14-fold (1.15 log units) above what was measured; measured number below the stated range.
By their numbers in this assay, from the lowest: compound 3; then compounds 1 and 2 (each within the scatter of the next).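

The group on the sulfonyl sulfur matters greatly in this assay: 4-bromophenyl in place of 3-nitrophenyl gives a 16-fold lower number from compound 2 to compound 3 (1.20 log units; beyond the scatter), and 4-bromophenyl in place of 3-cyanophenyl gives a 13-fold lower number from compound 1 to compound 3 (1.10 log units; beyond the scatter). Going by these compounds alone, the earlier pair showed only that nitro and cyano on that ring gave numbers within the scatter of each other, whereas these steps are the first sign that the read-out can respond strongly to a change at this place, and with both steps beyond the scatter, compound 3 is the strongest inhibitor of the three. No measurement shown here accounts for the size of these steps.

This exchange alters both the substituent and its place on the ring, so the compounds shown cannot tell whether the bromine, its place or the two together lie behind the drop in the number. A 3-bromophenyl and a 4-nitrophenyl on the sulfonyl sulfur would pull those two changes apart, while a 4-chlorophenyl or a plain phenyl would show how much depends on bromine itself.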